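The source may report more compounds than this note shows. Statements on the series, on what has been measured and on what is new or still open speak of the compounds shown alone.

Measured in a functional assay on K562 cells (Homo sapiens), read by MTT assay, with a stated time of 72 h; on this read-out higher numbers stand for weaker inhibition and lower numbers for stronger inhibition:
Compound 1 `O=c1[nH]cnc2c1c(-c1ccoc1)cn2[C@@H]1O[C@H](CO)[C@@H](O)[C@H]1O` gives 14500 nM.
Compound 2 `CN(C)c1ncnc2c1c(-c1ccsc1)cn2[C@@H]1O[C@H](CO)[C@@H](O)[C@H]1O` gives only the limit > 20000 nM.
Compound 3 `Cc1ncnc2c1c(I)cn2[C@@H]1O[C@H](CO)[C@@H](O)[C@H]1O` gives only the limit > 20000 nM.

Compound 2 stands at the limit of > 20000 nM in this assay, at which 2 of the 3 values shown sit; this is a limit of the assay and not a number, and compound 1 is the only one of the three with a measured value in this assay. Compound 4 `CN(C)c1ncnc2c1c(-c1ccoc1)cn2[C@@H]1O[C@H](CO)[C@@H](O)[C@H]1O` has not been measured in this assay. It differs from compound 2 by furan-3-yl in place of thiophen-3-yl on an aromatic carbon. Within the data shown here, no step between measured compounds is available to size this change. Compound 1 also carries furan-3-yl, but on a different core, so its value says little about compound 4. The step is expected to be small, a number no higher from compound 2 to compound 4 (the limit leaves the size open), with no direction beyond the scatter. Compound 4 is estimated at 20000 nM, range 8000 nM to 50000 nM, with a fair chance that only a limit is reported.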

Compound 4, half-maximal inhibitory concentration: 14900 nM
Estimate against measurement, compound 4: 1.3-fold (0.13 log units) above, and the stated range covers the measured number.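

In this assay, furan-3-yl in place of thiophen-3-yl on this aromatic carbon gives an at least 1.3-fold lower number from compound 2 to compound 4 (0.12 log units; that floor lies within the scatter). With furan-3-yl, the core shared by compound 2 and compound 4 now has a measured number rather than only a limit, so this position can be followed on a real value. The true size of the step stays open because one end of it is a limit: the limit of > 20000 nM in this assay, at which 2 of the 4 values shown sit.

From the compounds shown here alone, how the number moves at this position with a group other than a five-membered aromatic ring, such as an amine or a carboxylic acid, remains open.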